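The source may hold more compounds than are shown below. What is called first, only, known or untested is meant among the compounds shown, and "the series" means these compounds.

Compound 1 `C#Cc1cccc(Nc2ncnc3ccc(NC(=S)Nc4ccc(S(N)(=O)=O)cc4)cc23)c1`, compound 2 `NS(=O)(=O)c1ccc(NC(=S)Nc2ccc3ncnc(Nc4ccc(C(F)(F)F)cc4)c3c2)cc1` and compound 3 `NS(=O)(=O)c1ccc(NC(=S)Nc2ccc3ncnc(Nc4cccc(Cl)c4F)c3c2)cc1` make up the measured set, all three sharing one core and differing only in the group carried on a nitrogen on an aromatic ring.

In a functional assay on A549 cells (Homo sapiens) for antiproliferative activity, read by MTT assay, with a stated time of 72 h (on this read-out lower numbers stand for stronger inhibition and higher numbers for weaker inhibition), compound 1 reaches only the limit > 40000 nM. Compound 2 likewise stops at the limit > 40000 nM. Compound 3 too gives only the limit > 40000 nM. Compound 3 therefore stands at the limit of > 40000 nM in this assay, at which 3 of the 3 values shown sit, without a number of its own. Compound 4 `Cc1ccc(Nc2ncnc3ccc(NC(=S)Nc4ccc(S(N)(=O)=O)cc4)cc23)cc1` differs from it by 4-methylphenyl in place of 3-chloro-2-fluorophenyl on a nitrogen on an aromatic ring. The measured steps that exchange this same group, a step that the two limits leave unreadable from compound 1 to compound 2, a step that the two limits leave unreadable from compound 1 to compound 3 and a step that the two limits leave unreadable from compound 2 to compound 3, show no readable size, so no direction can be drawn from them. Compound 4 is expected to shift by a step that the limit leaves unreadable from compound 3 to compound 4, staying close to the limit. Compound 4 is accordingly estimated at 50000 nM, within 10000 nM to 200000 nM.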

Compound 4, half-maximal inhibitory concentration: 2840 nM
Compound 4: middle estimate off by 18-fold (1.25 log units), on the high side; measured number outside the range, below it.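

Among these compounds, compound 4 shows that this position can carry measurable activity in this assay, which the earlier compounds could not show, as each stopped at a limit: the limit of > 40000 nM in this assay, at which 3 of the 4 values shown sit. The 4-methylphenyl group gives an at least 14-fold lower number from compound 3 to compound 4 (1.14 log units; beyond the scatter) and an at least 14-fold lower number from compound 1 to compound 4 (1.14 log units; beyond the scatter), while methyl in place of trifluoromethyl on an aromatic carbon gives an at least 14-fold lower number from compound 2 to compound 4 (1.14 log units; beyond the scatter). The steps among the three limited compounds cannot be read, so they remain unranked. From the compounds shown here alone, it remains open whether an ethyl group, a methoxy group or an amine in place of that methyl would keep this activity.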